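A methyl group added to the core of compound 1

The compounds below may be only part of what the source reports. "The series", "measured", "known", "first", "only" and "open" are said of these compounds alone.

Values so far in a physicochemical assay for lipophilicity; on this read-out higher numbers stand for higher lipophilicity and lower numbers for lower lipophilicity
- compound 1 `COc1c(OC)c(OC(=O)C(C)C)c2ccccc2c1OC(=O)C(C)C` gives 4.61
- compound 2 `COc1c(OC)c(OC(=O)C(C)C)c2cc(Cl)ccc2c1OC(=O)C(C)C` gives 5.4
- compound 3 `COc1c(OC)c(OC(C)=O)c2c(NC(C)=O)cccc2c1OC(C)=O` gives 2

Compound 1 stands second highest of the three, under compound 2 and well over compound 3. Compound 4 `COc1c(OC)c(OC(=O)C(C)C)c2c(C)cccc2c1OC(=O)C(C)C` carries methyl in place of hydrogen on an aromatic carbon of the core of compound 1 (methyl in place of hydrogen on an aromatic carbon). For the measured compounds named here, only one measured step bears on this, chloro in place of hydrogen on an aromatic carbon, which runs a number 0.79 log units higher from compound 1 to compound 2 (beyond the scatter) and is modest, though beyond the scatter. A rise of somewhat smaller size is therefore expected in this assay, an estimated a number 0.39 log units higher from compound 1 to compound 4 (beyond the scatter) for this change. Compound 4 is expected at 5 in a range from 4.6 to 5.4 by this estimate.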

Compound 4, partition coefficient: 5
For compound 4 middle estimate and measured number coincide at the digits printed, within the range that was stated.
By their numbers in this assay, from the lowest: compound 3; then compound 1; then compound 4; then compound 2.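

In this assay the read-out is a number 0.39 log units higher from compound 1 to compound 4 (beyond the scatter) when methyl takes the place of hydrogen on an aromatic carbon of the core, ortho to a fused ring. This shows that so small a change at this place, a single added carbon, moves the number beyond the scatter. No measured evidence accounts for the step.

The compounds shown leave open whether a longer chain such as ethyl, or an amine, on this carbon would move the number the same way. They also leave open how methyl and chloro compare on the same carbon.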